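From compound 1 to compound 4: a change on sulfonyl sulfur

This account rests on a few compounds, and the source may have more. Where it says the series, first, only, none or still open, it means among the compounds named here.

Compound 1 `COc1cc(OC)c(/C=C/S(=O)(=O)Cc2cnc(Cl)cn2)c(OC)c1`: > 10000 nM
Compound 2 `COc1cc(OC)c(/C=C/S(=O)(=O)Cc2cnc(OC)cn2)c(OC)c1`: 950 nM
Compound 3 `COc1cc(OC)c(/C=C/S(=O)(=O)Cc2cnc(OC)c(OC)c2)c(OC)c1`: 2810 nM

In a functional assay on HCT-116 cells (Homo sapiens) for antiproliferative activity, read by MTT assay, with a stated time of 72 h (on this read-out lower numbers stand for stronger inhibition of growth and higher numbers for weaker inhibition of growth), compound 1 gives only a limit, not a number: the limit of > 10000 nM in this assay, at which 1 of the 3 values shown sits. Compound 4 `COc1cc(OC)c(/C=C/S(=O)(=O)Nc2cnc(Cl)cn2)c(OC)c1` is still unmeasured. It differs from compound 1 as follows: (5-chloropyrazin-2-yl)amino in place of (5-chloropyrazin-2-yl)methyl on a sulfonyl sulfur. In words, (5-chloropyrazin-2-yl)amino stands in place of (5-chloropyrazin-2-yl)methyl on a sulfonyl sulfur. Among the measured compounds shown here, the only measured step, an at least 10-fold lower number from compound 1 to compound 2 (1.02 log units; beyond the scatter), was large, but it is methoxy in place of chloro on an aromatic carbon, a change that compound 4 does not make. For the measured compounds named here, no measured step covers the change at the sulfonyl sulfur, so only a modest shift towards lower numbers in this assay is expected. The estimated step is an at least 1.6-fold lower number from compound 1 to compound 4 (0.22 log units; that floor lies within the scatter). Compound 4 is expected at 6000 nM, with an estimated range of 2000 nM to 18000 nM.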

Compound 4, concentration for 50% growth inhibition: > 10000 nM
Compound 4: no number, only a limit (the forecaster's own chance of this, stated with the estimate: 40%); middle value at least 1.6-fold (0.22 log units) from the limit.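

In this assay compound 1 and compound 4 each give only a limit, so the step between them cannot be read. The compounds shown leave open whether (5-chloropyrazin-2-yl)amino in place of (5-chloropyrazin-2-yl)methyl on a sulfonyl sulfur changes growth inhibition at all.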